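Replacing the ring on compound 3 with a carbamoylmethyl group

The source may report more compounds than this note shows. Statements on the series, on what has been measured and on what is new or still open speak of the compounds shown alone.

Measured so far:
- compound 1, `CC(C)C(c1ncc[nH]1)c1ccc(-c2ccc3cccc(F)c3c2)[nH]c1=O`: < 0.0667 h
- compound 2, `CC(C)C(c1ccc(-c2ccc3cccc(F)c3c2)[nH]c1=O)N1CCCCC1=O`: 0.102 h
- compound 3, `CC(C)C(/C=C1\CCNC1=O)c1ccc(-c2ccc3cccc(F)c3c2)[nH]c1=O`: 0.345 h

All three share one core and differ only in the group on a saturated chain carbon bound to an aromatic carbon and a saturated chain carbon. In an ADME assay on microsomes from liver (Rattus norvegicus) for metabolic stability (a higher number here means that the compound lasts longer, a lower number that the compound disappears faster), compound 1 gives < 0.0667 h, which is a limit of the assay rather than a number. Compound 2 reaches 0.102 h, a rise of an at least 1.5-fold higher number from compound 1 to compound 2 (0.18 log units; that floor lies within the scatter). Compound 3 stands highest of the two numbers, at 0.345 h: the step of a 3.4-fold higher number from compound 2 to compound 3 (0.53 log units; beyond the scatter) and the step of an at least 5.1-fold higher number from compound 1 to compound 3 (0.71 log units; beyond the scatter) both lie beyond the scatter.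

Compound 4, `CC(C)C(CC(N)=O)c1ccc(-c2ccc3cccc(F)c3c2)[nH]c1=O`, has not yet been measured. It differs from compound 3 by a group of 4 heavy atoms (2 carbon, 1 nitrogen, 1 oxygen; no ring) in place of a group of 7 heavy atoms (5 carbon, 1 nitrogen, 1 oxygen; one five-membered non-aromatic ring with 1 hetero atom), on a saturated chain carbon bound to an aromatic carbon and a saturated chain carbon. The measured steps show that the smaller groups on this carbon, in compound 1 and compound 2, gave lower numbers than the ring of compound 3, so the change to the even smaller acyclic group is expected to lower the half-life, by a modest step, a 1.9-fold lower number from compound 3 to compound 4 (0.28 log units; within the scatter). Compound 4 is therefore estimated at 0.18 h, in the range 0.07 h to 0.45 h.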

Compound 4, half-life: < 0.0667 h
Compound 4: only a limit was reported (the forecaster's own chance of this, stated with the estimate: 15%); middle value at least 2.6-fold (0.43 log units) away from the limit.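

In this assay, exchanging the five-membered ring for carbamoylmethyl gives an at least 5.1-fold lower number from compound 3 to compound 4 (0.71 log units; beyond the scatter), although both groups count the same hydrogen-bond donors and acceptors, so those counts alone do not hold up the half-life at this position. The comparison with the six-membered ring group gives an at least 1.5-fold lower number from compound 2 to compound 4 (0.18 log units; that floor lies within the scatter), which does not separate those two compounds with any confidence. Compound 4 returns only a limit of the assay, not a number, as does compound 1, so the step between them cannot be read: the limit of < 0.0667 h in this assay, at which 2 of the 4 values shown sit.

As far as these compounds go, it remains open whether the ring itself or the double bond linking it to the saturated chain carbon matters more, which a saturated 2-oxopyrrolidin-3-ylmethyl group could test. A longer chain ending in the same amide, an amine or a carboxylic acid on this carbon would show how far the open-chain result extends.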